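Swapping Chloro for Fluoro in a Paw-Edema Series

This account rests on a few compounds, and the source may have more. Where it says the series, first, only, none or still open, it means among the compounds named here.

Of the compounds shown here, three on one shared core have been tested in a functional assay on the whole organism (strain Wistar) for inhibition, with Rattus norvegicus as the target, read by paw edema, with stated times of 30 min and 5 h, at a dose of 0.05 mmol/kg by the oral route; a lower number here means less inhibition, a higher number more inhibition at the dose given (going by the name of the read-out). Compound 1 `COc1ccc(C2=NN(c3ccc(S(C)(=O)=O)cc3)C(=O)CC2)cc1` gives 68.4%, compound 2 `CS(=O)(=O)c1ccc(N2N=C(c3ccccc3)CCC2=O)cc1` gives 47.3%, and compound 3 `CS(=O)(=O)c1ccc(N2N=C(c3ccc(Cl)cc3)CCC2=O)cc1` gives 36.8%, the lowest of the three numbers; the steps down to it are a number 31.6 percentage points lower from compound 1 to compound 3 (beyond the scatter) and a number 10.5 percentage points lower from compound 2 to compound 3 (beyond the scatter). Compound 4 `CS(=O)(=O)c1ccc(N2N=C(c3ccc(F)cc3)CCC2=O)cc1` differs from compound 3 by fluoro in place of chloro on an aromatic carbon. Within the data shown here, no measured step exchanges one halogen for another, so the only guide is the fall of a number 10.5 percentage points lower from compound 2 to compound 3 (beyond the scatter) when chloro entered for hydrogen, a modest step. Compound 4 is therefore expected to shift by a number 5.2 percentage points higher from compound 3 to compound 4 (within the scatter), at most a small upward move. Compound 4 is estimated at 42%, with a likely range from 30% to 55% in this assay.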

Compound 4, a percentage reported as inhibition, in the whole organism at one dose (the size of the read-out at that dose, not a potency): 73.6%
Estimate against measurement, compound 4: 31.6 percentage points below; measured number outside the range, above it.
By their numbers in this assay, from the lowest: compound 3; then compound 2; then compounds 1 and 4 (each within the scatter of the next).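

In this assay, the change from 4-chlorophenyl to 4-fluorophenyl gives a number 36.8 percentage points higher from compound 3 to compound 4 (beyond the scatter), so on this aromatic carbon, para to a large group, the identity of the halogen matters greatly. Fluoro and chloro also depart from hydrogen in opposite directions: a number 26.3 percentage points higher from compound 2 to compound 4 (beyond the scatter) stands against the fall seen with chloro, while a number 5.2 percentage points higher from compound 1 to compound 4 (within the scatter) leaves fluoro and methoxy indistinguishable. Nothing available explains why the two halogens differ. Going by these compounds, what bromo, an amine or a carboxylic acid would give on this same carbon remains open.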